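The source may hold more compounds than are shown below. What is called first, only, known or untested is meant among the compounds shown, and "the series" means these compounds.

In a functional assay on HepG2 cells (Homo sapiens) for inhibition, read by MTT assay, with a stated time of 72 h (on this read-out higher numbers stand for weaker inhibition and lower numbers for stronger inhibition), compound 1 `N#Cc1ccccc1-n1cc(COc2cccc(NC(=O)Nc3ccc(Cl)c(C(F)(F)F)c3)c2)nn1` gives 1970 nM, the lowest of the three numbers recorded, although compound 3 `O=C(Nc1cccc(OCc2cn(-c3ccccc3Br)nn2)c1)Nc1ccc(Cl)c(C(F)(F)F)c1`, which gives 2810 nM, sits within the scatter of it. Compound 2 `CCc1cccc(-n2cc(COc3cccc(NC(=O)Nc4ccc(Cl)c(C(F)(F)F)c4)c3)nn2)c1` gives 37900 nM. The step of a 1.4-fold higher number from compound 1 to compound 3 (0.15 log units; within the scatter) stayed within the scatter, whereas a 19-fold higher number from compound 1 to compound 2 (1.28 log units; beyond the scatter) and a 13-fold lower number from compound 2 to compound 3 (1.13 log units; beyond the scatter) were both large. Compound 4 `O=C(Nc1cccc(OCc2cn(-c3ccccc3I)nn2)c1)Nc1ccc(Cl)c(C(F)(F)F)c1` has not yet been measured in this assay; it differs from compound 1 at one point: iodo in place of cyano on an aromatic carbon. The step that bears on this change is a 1.4-fold higher number from compound 1 to compound 3 (0.15 log units; within the scatter), which lay within the scatter, so no step beyond the scatter is expected in this assay. Compound 4 is therefore estimated to give about 2500 nM, within 1200 nM to 6000 nM. The expected step is a 1.3-fold higher number from compound 1 to compound 4 (0.10 log units; within the scatter).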

Compound 4, half-maximal inhibitory concentration: 2870 nM
Compound 4: the middle estimate sits 1.1-fold (0.06 log units) below what was measured; low and high end bracket the measured number.
By their numbers in this assay, from the lowest: compounds 1, 3 and 4 (each within the scatter of the next); then compound 2.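

Iodo behaves like the earlier groups on this aromatic carbon in this assay: a 1.5-fold higher number from compound 1 to compound 4 (0.16 log units; within the scatter) and a 1.0-fold higher number from compound 3 to compound 4 (0.01 log units; within the scatter) both stay within the scatter, so cyano, bromo and iodo cannot be told apart here, despite the loss of the nitrile's triple bond and hydrogen-bond acceptor. The 3-ethylphenyl compound remains apart, with a 13-fold lower number from compound 2 to compound 4 (1.12 log units; beyond the scatter) being large. Nothing available explains this pattern.

Going by these compounds, it remains open whether an amine or a carboxylic acid on this carbon would fit the same range. The compounds shown also cannot separate the ethyl group's identity from its place, as neither 2-ethylphenyl nor 3-bromophenyl appears among them.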